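This account rests on a few compounds, and the source may have more. Where it says the series, first, only, none or still open, it means among the compounds named here.

The compounds share one core and differ only in the chain on the ring nitrogen. Compound 1 `COC(C)CCOCn1cc[n+](C)c1/C=N/O` gives -2.22 in a physicochemical assay for lipophilicity; a lower number here means a more polar compound, a higher number a more lipophilic compound. Compound 2 `C[n+]1ccn(CCC#N)c1/C=N/O` gives -3.3 in this assay, the lowest of the two plain numbers, with compound 1 the nearest and sitting higher by more than the scatter. Compound 3 `C[n+]1ccn(COCCS(C)(=O)=O)c1/C=N/O` reaches only a limit of this assay, < -3.3, so no number is known for it (the limit of < -3.3 in this assay, at which 1 of the 3 values shown sits). Among the compounds with values here, the one step that was measured, a number at least 1.08 log units lower from compound 1 to compound 3 (beyond the scatter), fell by a large amount.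

Compound 4 `CN(C)CCn1cc[n+](C)c1/C=N/O` differs from compound 2 by dimethylamino in place of cyano on a saturated chain carbon, two bonds along the chain from an aromatic nitrogen. Within the data shown here, no measured step exchanges a cyano for a dimethylamino, so the measured step of compound 1 to compound 3 does not bear on it directly; it only shows how far this series can fall. For compound 4 a small move is expected in this assay, a number 0.30 log units higher from compound 2 to compound 4 (within the scatter), with either direction possible. Compound 4 is estimated at -3, within -3.6 to -2.4.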

Compound 4, distribution coefficient: -3.06
Compound 4: the middle estimate sits 0.06 log units above what was measured, and the stated range covers the measured number.
By their numbers in this assay, from the lowest: compounds 2 and 4 (each within the scatter of the next); then compound 1.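

In this assay the exchange of cyano for dimethylamino, on a saturated chain carbon, two bonds along the chain from an aromatic nitrogen, comes to a number 0.24 log units higher from compound 2 to compound 4 (within the scatter) and so cannot be told apart from repeat measurement. The earlier compounds shown here showed only a large step, on chains that carry an oxygen; here two different end groups give readings that sit together. Both groups count 1 hydrogen-bond acceptor and no donor, but this one pair cannot say whether that shared count matters.

A carboxylic acid or a longer chain at the same place would show how far the reading can move. Compound 3 stands only at a limit, so its place among the others stays unread: the limit of < -3.3 in this assay, at which 1 of the 4 values shown sits.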